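Hydroxamic acids: oxadiazole in place of terminal phenyl

The source may report more compounds than this note shows. Statements on the series, on what has been measured and on what is new or still open speak of the compounds shown alone.

Measured so far:
compound 1 `O=C(NO)c1cccc(OCc2ccc(-c3ccccc3)cc2)c1` — 19600 nM
compound 2 `COc1ccc(C(=O)NO)cc1OCc1ccc(-c2ccccc2)cc1` — 3630 nM

In an assay on isolated protein for inhibition of sphingomyelin phosphodiesterase (Homo sapiens), read by fluorescence, with a stated time of 30 min (on this read-out higher numbers stand for weaker inhibition and lower numbers for stronger inhibition), compound 1 gives the highest of the two numbers; the nearest is compound 2, reached by a 5.4-fold lower number from compound 1 to compound 2 (0.73 log units; beyond the scatter) with methoxy in place of hydrogen on an aromatic carbon. Compound 3 `CCc1nc(-c2ccc(COc3cccc(C(=O)NO)c3)cc2)no1` differs from compound 1 by 5-ethyl-1,2,4-oxadiazol-3-yl in place of phenyl on an aromatic carbon. Among the compounds with values here, no measured step touches this position, and the one measured step concerns another place, so it does not bear on the change. The expectation is a step of a 1.3-fold lower number from compound 1 to compound 3 (0.12 log units; within the scatter), no direction favoured beyond the scatter. Compound 3 is estimated at 15000 nM, within 4000 nM to 60000 nM.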

Compound 3, half-maximal inhibitory concentration: 34700 nM
Compound 3: the middle estimate sits 2.3-fold (0.36 log units) below what was measured; low and high end bracket the measured number.
By their numbers in this assay, from the lowest: compound 2; then compounds 1 and 3 (each within the scatter of the next).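

In this assay the exchange of phenyl for 5-ethyl-1,2,4-oxadiazol-3-yl gives a 1.8-fold higher number from compound 1 to compound 3 (0.25 log units; within the scatter) and so leaves no readable change. At this place on an aromatic carbon, a six-membered ring of carbon only and a five-membered aromatic ring with 3 hetero atoms and 3 hydrogen-bond acceptors are not told apart by this read-out. No supporting data bear on this result.

From the compounds shown here alone, a longer chain in place of the ethyl, or an amine on the five-membered ring, remains open. Also open, going by these compounds, is whether a 5.4-fold lower number from compound 1 to compound 2 (0.73 log units; beyond the scatter) recurs with 5-ethyl-1,2,4-oxadiazol-3-yl present.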